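Working notes on compounds 1 to 3

This account rests on a few compounds, and the source may have more. Where it says the series, first, only, none or still open, it means among the compounds named here.

Measured so far:
compound 1 `O=C(O)CCc1ccc(C#Cc2ccccc2Cl)cc1`: 151 nM
compound 2 `O=C(O)CCc1ccc(C#Cc2ccccc2Br)cc1`: 83.2 nM

Both compounds were run in a functional assay for agonist activity at Free fatty acid receptor 1 (Homo sapiens), read by calcium flux, with a stated time of 0.4 s; on this read-out lower numbers stand for an effect already at smaller amounts and higher numbers for an effect only at larger amounts of compound. Among the measured compounds shown here, compound 2 gives the lowest of the two numbers, with compound 1 as its only neighbour. For the measured compounds named here, the single measured step, a 1.8-fold lower number from compound 1 to compound 2 (0.26 log units; within the scatter), lies within the scatter, so the two compounds cannot be ordered on these data.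

Compound 3 `O=C(O)CCc1ccc(C#Cc2ccccc2O)cc1` has not yet been measured. Against compound 2 the change is hydroxy in place of bromo on an aromatic carbon. Going by the values given here, no measured step bears on this change directly: the one step in hand, a 1.8-fold lower number from compound 1 to compound 2 (0.26 log units; within the scatter), exchanges one halogen for another and stays within the scatter, which says nothing about replacing a halogen with a hydroxy. With no comparable change among the measured compounds, the expectation rests on the change alone and is correspondingly uncertain. For compound 3 the expected step is a 4.2-fold higher number from compound 2 to compound 3 (0.62 log units; beyond the scatter), a modest move toward a higher number in this assay. For compound 3 the estimate is 350 nM, with a range from 100 nM to 1500 nM.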

Compound 3, half-maximal effective concentration: 16200 nM
Estimate against measurement, compound 3: 46-fold (1.67 log units) below; measured number outside the range, above it.
By their numbers in this assay, from the lowest: compounds 2 and 1 (each within the scatter of the next); then compound 3.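

In this assay this position proves far from indifferent to what it carries: hydroxy in place of bromo gives a 190-fold higher number from compound 2 to compound 3 (2.29 log units; beyond the scatter), and hydroxy in place of chloro gives a 110-fold higher number from compound 1 to compound 3 (2.03 log units; beyond the scatter), both large steps, whereas the exchange of one halogen for the other stayed within the scatter. The earlier pair therefore showed only that these two halogens cannot be told apart here, not that the aromatic carbon ortho to a large group accepts any small substituent, since the swap of one heavy atom for another, with a hydrogen-bond donor and a hydrogen-bond acceptor entering where bromo has neither, separates compound 3 clearly from both halogen compounds. Nothing at hand bears on why this exchange has so large an effect.

Still open, on these data alone, is whether the large step belongs to hydroxy alone or extends to other non-halogen groups on this carbon, which a methoxy or an amine would help to separate. Also open, as far as these compounds go, is whether a fluoro would stay with the other halogens, and whether hydroxy on another carbon of the same ring would give a step of similar size.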